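A few compounds are considered here, and "the series" means these few. Any claim that something is new, unique, unknown or untested is made for them only; others in the source may bear on it.

Of the compounds shown here, three sharing one core have been measured in an assay on HEK293 cells for inhibition of acid ceramidase (Homo sapiens), with a stated time of 10 min; on this read-out higher numbers stand for weaker inhibition and lower numbers for stronger inhibition. Compound 1 `O=C(c1ccccc1)c1ccc2c(c1)oc(=O)n2C(=O)NCCCCc1ccccc1` gives 29 nM, compound 2 `COc1ccc(-c2ccc3c(c2)oc(=O)n3C(=O)NCCCCc2ccccc2)cc1` gives 67 nM, and compound 3 `Cc1ccc2c(c1)oc(=O)n2C(=O)NCCCCc1ccccc1` gives 66 nM. Compound 3 stands second highest of the three numbers; its nearest neighbour, compound 2, sits within the scatter of it, and only its gap to compound 1 lies beyond the scatter. Compound 4 `O=C(NCCCCc1ccccc1)n1c(=O)oc2cc(F)ccc21` differs from compound 3 by fluoro in place of methyl on an aromatic carbon. Within the data shown here, three measured steps concern that same aromatic carbon: a 2.3-fold higher number from compound 1 to compound 2 (0.36 log units; beyond the scatter), a 2.3-fold higher number from compound 1 to compound 3 (0.36 log units; beyond the scatter) and a 1.0-fold lower number from compound 2 to compound 3 (0.01 log units; within the scatter). Among the measured compounds shown here, the two steps that remove benzoyl are modest, while the one exchange that does not involve benzoyl stays within the scatter. The change from methyl to fluoro likewise does not involve benzoyl, so no step beyond the scatter is expected in this assay: a 1.1-fold higher number from compound 3 to compound 4 (0.03 log units; within the scatter). Compound 4 is therefore estimated at 70 nM in this assay, with an expected range from 35 nM to 140 nM.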

Compound 4, half-maximal inhibitory concentration: 31 nM
Compound 4: middle estimate off by 2.3-fold (0.35 log units), on the high side; measured number below the stated range.
By their numbers in this assay, from the lowest: compounds 1 and 4 (each within the scatter of the next); then compounds 3 and 2 (each within the scatter of the next).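

In this assay, exchanges at this aromatic carbon that do not involve benzoyl can now move the number beyond the scatter, as shown by a 2.1-fold lower number from compound 3 to compound 4 (0.33 log units; beyond the scatter) and by a 2.2-fold lower number from compound 2 to compound 4 (0.33 log units; beyond the scatter), whereas the earlier compounds showed such a shift only on removing benzoyl. Fluoro and benzoyl cannot be told apart here, with a 1.1-fold higher number from compound 1 to compound 4 (0.03 log units; within the scatter), so a group of a single heavy atom can match benzoyl at this position, while methyl, also a single heavy atom, does not. Nothing measured accounts for the difference between methyl and fluoro.

The compounds shown leave open whether chloro, an amine or a carboxylic acid on this carbon would align with fluoro or with methyl. They also leave open whether the fluoro-for-methyl step would persist with a shorter chain on the amide nitrogen.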